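Methyl in place of hydrogen on the shared core

A few compounds are considered here, and "the series" means these few. Any claim that something is new, unique, unknown or untested is made for them only; others in the source may bear on it.

Compound 2 `Cc1cc(C)nc(SCc2cc(=O)c3ccccc3o2)n1` stands at the edge of what a functional assay on LM7 cells (Homo sapiens) for cytotoxicity, read by MTT assay, with a stated time of 72 h (a lower number here means a stronger inhibitor, a higher number a weaker inhibitor), reports: in this assay compound 2 gives > 25000 nM, which is a limit of the assay and not a number. In this assay compound 1 `Cc1cc(C)nc(SCc2cc(=O)c3cc(Cl)ccc3o2)n1` gives > 25000 nM, likewise a limit. Compound 3 `O=c1c(CSc2nc3ccccc3o2)coc2ccccc12`, built on a different core, gives 5300 nM in this assay. Compound 4 `Cc1ccc2oc(CSc3nc(C)cc(C)n3)cc(=O)c2c1` differs from compound 2 by methyl in place of hydrogen on an aromatic carbon. Among the compounds with values here, the only single-point step among the measured compounds, a step that the two limits leave unreadable from compound 1 to compound 2, cannot be sized, and the limit of > 25000 nM in this assay, at which 2 of the 3 values shown sit, leaves no readable direction for a small substituent on this ring. Compound 4 is therefore expected to remain at or near the limit, with a step that the limit leaves unreadable from compound 2 to compound 4 as the expected step and an estimate of 30000 nM, ranging from 10000 nM to 100000 nM.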

Compound 4, half-maximal inhibitory concentration: > 25000 nM
Compound 4: no number, only a limit; the forecaster's own chance of this, stated with the estimate: 80%; the middle value is on the limit's open side.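

Compound 4 gives > 25000 nM, a limit and not a number. No step among compound 1, compound 2 and compound 4 can be read: the limit of > 25000 nM in this assay, at which 3 of the 4 values shown sit.

The compounds shown leave open whether any substituent at this place on the shared core gives a readable value.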